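Replacing the dibromophenyl group on the carbonyl carbon

The source may report more compounds than this note shows. Statements on the series, on what has been measured and on what is new or still open speak of the compounds shown alone.

In an assay for inhibition of HSP60/HSP10 (Homo sapiens), with a stated time of 60 min (on this read-out higher numbers stand for weaker inhibition and lower numbers for stronger inhibition), compound 1, `O=C(Nc1ccc(Sc2nc3ccccc3s2)c(Cl)c1)c1cc(Br)cc(Br)c1`, gives only an assay limit, > 100000 nM. Compound 2, `O=C(Nc1ccc(Sc2nc3ccccc3s2)cc1)c1cc(Br)cc(Br)c1`, likewise gives only a limit in this assay, > 100000 nM. Among the compounds with values here, the one measured step, a step that the two limits leave unreadable from compound 1 to compound 2, cannot be read because of the limit of > 100000 nM in this assay, at which 2 of the 2 values shown sit. So compound 2 stands at the limit of this assay, with no number of its own. Compound 3, `COc1c(Br)cccc1C(=O)Nc1ccc(Sc2nc3ccccc3s2)cc1`, differs from compound 2 by a group of 9 heavy atoms (7 carbon, 1 oxygen, 1 bromine; one six-membered aromatic ring of carbon only) in place of a group of 8 heavy atoms (6 carbon, 2 bromine; one six-membered aromatic ring of carbon only), on a carbonyl carbon. Within the data shown here, no measured step changes the group on the carbonyl carbon, so the measured data bear on this change only by showing that both compounds so far sit at the limit. For compound 3 in this assay a value of about 150000 nM is expected, within 30000 nM to 1000000 nM, most likely again reported only as a limit. The step that the limit leaves unreadable from compound 2 to compound 3 that this estimate means is expected to be unreadable or no larger than the scatter.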

Compound 3, half-maximal inhibitory concentration: > 100000 nM
Compound 3: a limit, no number (the forecaster's own chance of this, stated with the estimate: 75%); the middle value does not contradict the limit.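

The step from compound 2 to compound 3 cannot be read, since both compounds give only a limit in this assay and neither has a number of its own: the limit of > 100000 nM in this assay, at which 3 of the 3 values shown sit. The compounds shown leave open how strongly any of them inhibits, and whether exchanging the 3,5-dibromophenyl group changes that at all.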